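Trimethoxyphenyl Replaces Methoxyphenyl on the Triazole Core

The compounds below may be only part of what the source reports. "The series", "measured", "known", "first", "only" and "open" are said of these compounds alone.

Of the compounds shown here, three sharing a triazole core have been measured in a functional assay on the whole organism (strain albino) for inhibition, with Rattus norvegicus as the target, read by paw edema, with stated times of 30 min and 1 h, at a dose of 0.28 mmol/kg by the oral route; a lower number here means less inhibition, a higher number more inhibition at the dose given (going by the name of the read-out). Compound 1 `COc1cc(-c2nnc(SCC(=O)Nc3ccc(/C(C)=N/O)cc3)n2-c2ccccc2)cc(OC)c1OC` gives 59%. Compound 2 `CCn1c(SCC(=O)Nc2ccc(C(C)=O)cc2)nnc1-c1cc(OC)c(OC)c(OC)c1` gives 46%. Compound 3 `COc1ccc(-c2nnc(SCC(=O)Nc3ccc(C(C)=O)cc3)n2-c2ccccc2)cc1` gives 29%, the lowest of the three numbers; its distance to compound 2 and its larger distance to compound 1 both lie beyond the usual scatter.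

Compound 4 `COc1cc(-c2nnc(SCC(=O)Nc3ccc(C(C)=O)cc3)n2-c2ccccc2)cc(OC)c1OC` has not yet been measured in this assay. It differs from compound 3 in one place: 3,4,5-trimethoxyphenyl in place of 4-methoxyphenyl on an aromatic carbon. Within the data shown here, the two measured compounds that carry the 3,4,5-trimethoxyphenyl group, compound 1 at 59% and compound 2 at 46%, both stand well above compound 3, so a rise beyond the scatter is the expectation for this change, although no single-change step between measured compounds confirms it.

Compound 4 is therefore expected to reach 48%, with a range from 35% to 60%. The step of a number 19 percentage points higher from compound 3 to compound 4 (beyond the scatter) is thus estimated to be a clear rise in this assay.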

Compound 4, a percentage reported as inhibition, in the whole organism at one dose (the size of the read-out at that dose, not a potency): 49%
Compound 4: the middle estimate sits 1 percentage points below what was measured; low and high end bracket the measured number.
By their numbers in this assay, from the lowest: compound 3; then compounds 2, 4 and 1 (each within the scatter of the next, the first and the last beyond it).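

In this assay, among these compounds, the change to 3,4,5-trimethoxyphenyl in place of 4-methoxyphenyl on the aromatic carbon gives a number 20 percentage points higher from compound 3 to compound 4 (beyond the scatter), the first reading of this change in one place, and the rise lies beyond the scatter. With the 3,4,5-trimethoxyphenyl group kept, phenyl in place of ethyl on the aromatic nitrogen gives a number 3 percentage points higher from compound 2 to compound 4 (within the scatter), and a group of 3 heavy atoms in place of a group of 4 heavy atoms on the other aromatic carbon gives a number 10 percentage points lower from compound 1 to compound 4 (within the scatter), so neither of these two changes moves the number beyond the scatter. Nothing measured here accounts for the rise.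

The compounds shown leave open whether the rise carries over when ethyl stands on the ring nitrogen. They also leave open how a carboxylic acid or an amine on that phenyl ring would read in this assay.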